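Chloro for Hydrogen on the Core: Cytotoxicity Expected Unchanged

The source may report more compounds than this note shows. Statements on the series, on what has been measured and on what is new or still open speak of the compounds shown alone.

Compound 1 `CCc1ccn2c(CCCCO)c(Cn3c(=O)n(C4CC4)c4ccncc43)nc2c1` carries an ethyl group on an aromatic carbon of the shared core. In an ADME assay on HEp-2 cells (Homo sapiens) for cytotoxicity, read by CCK-8 assay, with a stated time of 6 days (a lower number here means that less compound is tolerated, a higher number that more compound is tolerated), compound 1 reaches only the limit of the assay, > 100000 nM, rather than a number. Compound 2 `O=c1n(Cc2nc3ccccn3c2CCCCO)c2cnccc2n1C1CC1` differs from it by a hydrogen in place of ethyl on an aromatic carbon. In this assay compound 2 likewise sits at the limit, > 100000 nM, and not at a number. The step that the two limits leave unreadable from compound 1 to compound 2 is therefore unreadable because both compounds sit at the limit of > 100000 nM in this assay, at which 2 of the 2 values shown sit. Compound 2 thus stands at the limit of this assay, with no number of its own.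

Compound 3 `O=c1n(Cc2nc3cc(Cl)ccn3c2CCCCO)c2cnccc2n1C1CC1` is the compound still to be measured; it differs from compound 2 by chloro in place of hydrogen on an aromatic carbon. Within the data shown here, no measured step bears on this change, since the only measured step is unreadable. The step that the limit leaves unreadable from compound 2 to compound 3 is expected to be none beyond the scatter. Compound 3 is estimated at 200000 nM, within 100000 nM to 1000000 nM, and is expected most likely to remain at the limit.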

Compound 3, half-maximal cytotoxic concentration: > 100000 nM
Compound 3 ended at the assay's limit; the forecaster's own chance of this, stated with the estimate: 85%; the middle value does not contradict the limit.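

Compound 3 also reaches only a limit in this assay, so its steps from compound 1 and compound 2 cannot be read, because all the compounds shown sit at one limit: the limit of > 100000 nM in this assay, at which 3 of the 3 values shown sit. As far as these compounds go, whether ethyl, hydrogen or chloro at this place differ in cytotoxicity remains open.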